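Benzyloxy acetophenones: methyl to trifluoromethyl exchange

The compounds below may be only part of what the source reports. "The series", "measured", "known", "first", "only" and "open" are said of these compounds alone.

Measured in an assay on isolated protein for inhibition of Amine oxidase [flavin-containing] B (Homo sapiens), read by Amplex Red, with a stated time of 15 min; on this read-out higher numbers stand for weaker inhibition and lower numbers for stronger inhibition:
Compound 1, `CC(=O)c1cccc(OCc2cccc(C)c2)c1`: compound 1 gives 893 nM.
Compound 2, `CC(=O)c1cccc(OCc2ccc(C)cc2)c1`: compound 2 gives 140 nM.
Compound 3, `CC(=O)c1cccc(OCc2cccc(C(F)(F)F)c2)c1`: compound 3 gives 21.2 nM.

Compound 1 and compound 2 hold the same atoms joined differently; the difference between the two cores is not broken down here. Their two values show compound 2 with the lower number. Compound 3 arises from compound 1 by trifluoromethyl in place of methyl on an aromatic carbon, and the step of a 42-fold lower number from compound 1 to compound 3 (1.62 log units; beyond the scatter) is large. Compound 4, `CC(=O)c1cccc(OCc2ccc(C(F)(F)F)cc2)c1`, is not yet measured in this assay and arises from compound 2 by trifluoromethyl in place of methyl on an aromatic carbon. This is the same kind of change, not the same: around the place, the change from compound 1 to compound 3 sits meta to a large group, whereas from compound 2 to compound 4 it sits para to a large group. For the measured compounds named here, the expected step is a 9.3-fold lower number from compound 2 to compound 4 (0.97 log units; beyond the scatter), taken somewhat smaller than a 42-fold lower number from compound 1 to compound 3 (1.62 log units; beyond the scatter) as the only precedent, with compound 2 starting from 140 nM. Compound 4 is therefore expected at about 15 nM, within 3 nM to 60 nM.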

Compound 4, half-maximal inhibitory concentration: 43.2 nM
For compound 4 the middle estimate is 2.9-fold (0.46 log units) below the measured one; measured number inside the range.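

In this assay, trifluoromethyl in place of methyl on an aromatic carbon again gives a lower number, here a 3.2-fold lower number from compound 2 to compound 4 (0.51 log units; beyond the scatter), so the direction of the step is shared by the two cores shown. The size of the step does not carry from one core to the other: the same change on two cores in this assay, a 42-fold lower number (1.62 log units; beyond the scatter) from compound 1 to compound 3 and a 3.2-fold lower number (0.51 log units; beyond the scatter) from compound 2 to compound 4, 13-fold (1.11 log units) apart, beyond the scatter of two such steps. Two pairs do not show whether the smaller step goes with the place of the change, para to a large group in compound 4, or with the lower starting number of compound 2 at 140 nM against compound 1 at 893 nM, and they set no general rule for this change across the series.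

The compounds shown leave open how a chlorine atom, a methoxy group or a nitrile would compare with methyl and trifluoromethyl at these places. They also leave open whether an amine or a carboxylic acid would be tolerated on either core.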